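A new group on the nitrogen of compound 3

A few compounds are considered here, and "the series" means these few. Any claim that something is new, unique, unknown or untested is made for them only; others in the source may bear on it.

Among the compounds with values here, in a functional assay on MOLT-4 cells (Homo sapiens) for inhibition, read by MTT assay, with a stated time of 48 h (a higher number here means a weaker inhibitor, a lower number a stronger inhibitor), compound 3 `O=C(/C=C/c1cn(-c2ccc(Cl)cc2)c2ccccc12)CC(=O)C(=O)O` gives 27000 nM and compound 2 `CC(C)CCn1cc(/C=C/C(=O)CC(=O)C(=O)O)c2ccccc21` gives 20000 nM as the only two numbers so far, and these two lie within the scatter of each other. Compound 1 `CCOC(=O)C(=O)CC(=O)/C=C/c1cn(Cc2ccc(C#N)cc2)c2ccccc12` also carries 4-cyanobenzyl, but its entry reads "not determined" (no result reported) and so offers no guide.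

Compound 4 `N#Cc1ccc(Cn2cc(/C=C/C(=O)CC(=O)C(=O)O)c3ccccc32)cc1` has not yet been measured. It has 4-cyanobenzyl in place of 4-chlorophenyl on an aromatic nitrogen of a five-membered aromatic ring, and the difference from compound 3 is 4-cyanobenzyl in place of 4-chlorophenyl on an aromatic nitrogen with the rest of the structure unchanged.

Within the data shown here, only one measured step touches this nitrogen: 4-chlorophenyl in place of isopentyl gave a 1.4-fold higher number from compound 2 to compound 3 (0.13 log units; within the scatter) and no more. Among the measured compounds shown here, one step is thin evidence, and no compound with 4-cyanobenzyl has a number yet. Even so, that single step gives no reason to expect a large change, so no step beyond the scatter is expected in this assay for this exchange. The estimate amounts to a 1.1-fold lower number from compound 3 to compound 4 (0.05 log units; within the scatter) as an expected step. Compound 4 is expected near 24000 nM with an estimated range of 11000 nM to 50000 nM across repeated measurements.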

Compound 4, half-maximal inhibitory concentration: > 40000 nM
Compound 4: a limit, no number; the forecaster's own chance of this, stated with the estimate: 10%; middle value at least 1.6-fold (0.22 log units) away from the limit.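

In this assay compound 4 gives a limit of the assay and not a number, and it is the only one of the compounds shown with a limit: the limit of > 40000 nM in this assay, at which 1 of the 4 values shown sits.

The exchange can therefore be read only as a floor, an at least 1.4-fold higher number from compound 3 to compound 4 (0.17 log units; that floor lies within the scatter), and the same holds for an at least 2.0-fold higher number from compound 2 to compound 4 (0.30 log units; that floor lies within the scatter), so the true size of either step may be small or may be larger. Across isopentyl, 4-chlorophenyl and 4-cyanobenzyl, this nitrogen now shows no step beyond the scatter, but the limit leaves the upward side open, which the two earlier numbers alone did not.

The exchange changes two things at once, phenyl to benzyl and chlorine to nitrile, so the compounds shown do not tell which of the two goes with the limit; a plain benzyl or a 4-chlorobenzyl on the same nitrogen would separate them. Also open, on these data alone, is how this assay responds to a quite different group at this position, such as a short chain ending in an amine or a carboxylic acid.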